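From 2-Chlorophenyl to 4-Methylphenyl on a Saturated Ring Carbon

This account rests on a few compounds, and the source may have more. Where it says the series, first, only, none or still open, it means among the compounds named here.

In a functional assay on A2780 cells (Homo sapiens) for antiproliferative activity, read by MTT assay, with a stated time of 72 h (a lower number here means a stronger inhibitor, a higher number a weaker inhibitor), compound 3 `O=C(c1cc2ccccc2o1)N1N=C(c2ccc(F)cc2)CC1c1ccccc1Cl` gives 45.2 ug/mL, the higher of the two numbers, and compound 1 `Cc1ccc(C2CC(c3ccccc3)=NN2C(=O)c2cc3ccccc3o2)cc1` gives the lower 16.6 ug/mL. Compound 2 `O=C(c1cc2ccccc2o1)N1N=C(c2ccc(F)cc2)CC1c1ccc(Cl)cc1` gives > 50 ug/mL, which is a limit of the assay. Compound 4 `Cc1ccc(C2CC(c3ccc(F)cc3)=NN2C(=O)c2cc3ccccc3o2)cc1` has 4-methylphenyl in place of 2-chlorophenyl on a saturated ring carbon. Among the compounds with values here, the only measured step at such a carbon, an at least 1.1-fold lower number from compound 2 to compound 3 (0.04 log units; that floor lies within the scatter), offers little guidance. Compound 1 also carries 4-methylphenyl, without the 4-fluorophenyl group, and its 16.6 ug/mL points to a lower number. A moderate change is therefore expected, a 1.7-fold lower number from compound 3 to compound 4 (0.24 log units; within the scatter). Compound 4 is estimated at 26 ug/mL, with an expected range of 12 ug/mL to 50 ug/mL.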

Compound 4, half-maximal inhibitory concentration: > 50 ug/mL
Compound 4 was reported as a limit; the forecaster's own chance of this, stated with the estimate: 10%; middle value at least 1.9-fold (0.28 log units) from the limit.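

In this assay, 4-methylphenyl in place of 2-chlorophenyl on this saturated ring carbon gives an at least 1.1-fold higher number from compound 3 to compound 4 (0.04 log units; that floor lies within the scatter), a floor too small to show the size of the change. The clearer result comes from the other end of the molecule, where fluoro in place of hydrogen on an aromatic carbon gives an at least 3.0-fold higher number from compound 1 to compound 4 (0.47 log units; beyond the scatter), so 4-methylphenyl alone does not keep the number low. The step from compound 2 to compound 4 cannot be read, both values being limits: the limit of > 50 ug/mL in this assay, at which 2 of the 4 values shown sit.

Still open, on these data alone, is how a methoxy group or an amine on the phenyl ring at this carbon would behave. Also open, as far as these compounds go, is whether removing the fluoro group from compound 3 would lower its number as well.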